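The compounds below may be only part of what the source reports. "The series", "measured", "known", "first", "only" and "open" are said of these compounds alone.

The three measured compounds share one core and differ only in the aryl group carried on the amine nitrogen. Compound 1 `Cc1ccc(NC2=CC(=O)c3nc4n(c3C2=O)[C@H]2OC[C@@H](O)[C@H]2OC4)cc1` gives 3860 nM in a functional assay on HeLa cells (Homo sapiens) for inhibition, read by sulforhodamine B assay; on this read-out higher numbers stand for weaker inhibition and lower numbers for stronger inhibition. Compound 2 `COc1ccc(NC2=CC(=O)c3nc4n(c3C2=O)[C@H]2OC[C@@H](O)[C@H]2OC4)cc1` gives 4780 nM in this assay. Compound 3 `CCOc1ccccc1NC1=CC(=O)c2nc3n(c2C1=O)[C@H]1OC[C@@H](O)[C@H]1OC3` gives 6040 nM in this assay. Compound 3 carries the highest of the three numbers, but both of its steps stay within the scatter: a 1.6-fold higher number from compound 1 to compound 3 (0.19 log units; within the scatter) and a 1.3-fold higher number from compound 2 to compound 3 (0.10 log units; within the scatter). Within the data shown here, the one step that does not involve compound 3, a 1.2-fold higher number from compound 1 to compound 2 (0.09 log units; within the scatter), is also within the scatter, so across these three compounds the aryl group on the amine nitrogen has not moved the read-out beyond the noise.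

Compound 4 `COc1ccccc1NC1=CC(=O)c2nc3n(c2C1=O)[C@H]1OC[C@@H](O)[C@H]1OC3` is reached from compound 3 by a single change: hydrogen in place of methyl on a saturated chain carbon bound to an oxygen on an aromatic ring. Among the measured compounds shown here, no measured step removes a methyl from a saturated chain carbon bound to an oxygen on an aromatic ring; the nearest comparison is the exchange of methyl for methoxy on an aromatic carbon between compound 1 and compound 2, which stayed within the scatter. Nothing in the measured steps therefore points to a move beyond the scatter, and the expected step is a 1.1-fold lower number from compound 3 to compound 4 (0.04 log units; within the scatter). Compound 4 is estimated at 5500 nM in this assay, with a range from 2500 nM to 12000 nM.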

Compound 4, half-maximal inhibitory concentration: 2950 nM
Compound 4: middle estimate off by 1.9-fold (0.27 log units), on the high side; low and high end bracket the measured number.
By their numbers in this assay, from the lowest: compounds 4, 1, 2 and 3 (each within the scatter of the next, the first and the last beyond it).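

In this assay, among these compounds, the loss of a single methyl from the saturated chain carbon bound to an oxygen on an aromatic ring, which turns ethoxy into methoxy, gives the first step that passes the scatter, a 2.0-fold lower number from compound 3 to compound 4 (0.31 log units; beyond the scatter), although that step is modest. The other two new steps stay within the scatter, a 1.6-fold lower number from compound 2 to compound 4 (0.21 log units; within the scatter) and a 1.3-fold lower number from compound 1 to compound 4 (0.12 log units; within the scatter), so 2-methoxyphenyl on the amine nitrogen stands apart only from 2-ethoxyphenyl and not from 4-methoxyphenyl or 4-methylphenyl. Nothing at hand explains why this one methyl makes a difference.

The result rests on a single pair, so the compounds shown leave open whether a longer chain such as propoxy would continue the same trend, or whether a free hydroxyl in place of the ethoxy would extend it further. They also leave open whether an amine or a carboxylic acid on the aryl group would move the read-out beyond the scatter from all of the compounds shown here.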